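Swapping propyl for isopropyl on compound 3

This account rests on a few compounds, and the source may have more. Where it says the series, first, only, none or still open, it means among the compounds named here.

Compound 1 `O=C(NO)c1cc2ccn(Cc3cccc(Cl)c3F)c2cn1`: > 320000 nM (a limit)
Compound 2 `NC(=O)c1cccc(Cn2ccc3cc(C(=O)NO)ncc32)c1`: > 10000 nM (a limit)
Compound 3 `CCCN(O)C(=O)c1cc2ccn(Cc3ccc(F)cc3)c2cn1`: 26000 nM

Going by the values given here, in an ADME assay on CEM-SS cells (Homo sapiens) for cytotoxicity, read by XTT assay (on this read-out lower numbers stand for higher toxicity in this test and higher numbers for lower toxicity in this test), compound 3 gives 26000 nM, the only true number of the three. The entries for compound 1 and compound 2 are limits of this assay, not numbers.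

Compound 4 `CC(C)N(O)C(=O)c1cc2ccn(Cc3ccc(F)cc3)c2cn1` has the same atoms as compound 3, joined differently: isopropyl in place of propyl on an amide-type nitrogen. Isopropyl stands in place of propyl on an amide-type nitrogen. Among the compounds with values here, no measured pair shows this change, and the only anchor is compound 3 at 26000 nM, so no shift beyond the usual scatter is expected. The estimated step is a 1.2-fold higher number from compound 3 to compound 4 (0.06 log units; within the scatter). Compound 4 is expected at 30000 nM, with an estimated range of 11000 nM to 80000 nM.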

Compound 4, half-maximal cytotoxic concentration: 36000 nM
For compound 4 the middle estimate is 1.2-fold (0.08 log units) below the measured one, within the range that was stated.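

In this assay, going by these compounds alone, isopropyl in place of propyl on the amide-type nitrogen gives a 1.4-fold higher number from compound 3 to compound 4 (0.14 log units; within the scatter) and this is the only measured pair at this position. On this nitrogen, then, the two chains, made of the same atoms joined differently, cannot be told apart in this test. Nothing at hand bears on why this is so.

Still open, from the compounds shown here alone, is whether a longer chain such as butyl, or a chain ending in an amine or a carboxylic acid, would shift the number beyond the scatter.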